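Moving a Pyridine Nitrogen: From Compound 1 to Compound 3

The source may hold more compounds than are shown below. What is called first, only, known or untested is meant among the compounds shown, and "the series" means these compounds.

Compound 1 `O=C1OC(c2ccc(Cl)c([N+](=O)[O-])c2)=N/C1=C\c1ccncc1` was tested in an assay on isolated protein for inhibition of Death-associated protein kinase 3 (Homo sapiens), tested at 1 uM (a higher number here means a stronger effect of the compound at the concentration tested, a lower number a weaker effect), and gave 0%. This is the lowest of the two numbers recorded so far; the nearest is compound 2 `O=C1OC(c2cccc(Br)c2)=N/C1=C\c1ccncc1`, which in this assay gives 1%, a result that lies within the usual scatter of repeated measurements, so the two compounds cannot be told apart on these numbers. Compound 3 `O=C1OC(c2ccc(Cl)c([N+](=O)[O-])c2)=N/C1=C\c1cccnc1` has not yet been measured. It differs from compound 1 in one place: pyridin-3-yl in place of pyridin-4-yl on a double-bonded chain carbon bound to a double-bonded ring carbon. Among the compounds with values here, no measured pair shows what such a change does here, so the expectation rests only on the low numbers already seen. Since both recorded numbers sit near the bottom of the scale, the step of a number 4 percentage points higher from compound 1 to compound 3 (within the scatter) is expected to be small, with no direction beyond the scatter. Compound 3 is therefore estimated at 4%, with a range from 0% to 20%.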

Compound 3, a percentage reported as inhibition, at one concentration (the size of the read-out at that concentration, not a potency): 100%
The estimate for compound 3 lay 96 percentage points below the measured number; the whole stated range lies below it.
By their numbers in this assay, from the lowest: compounds 1 and 2 (each within the scatter of the next); then compound 3.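

In this assay, within the data shown here, putting pyridin-3-yl in place of pyridin-4-yl on the double-bonded chain carbon gives a number 100 percentage points higher from compound 1 to compound 3 (beyond the scatter), so the read-out at this position depends strongly on where the pyridine nitrogen sits, something the earlier compounds, both carrying pyridin-4-yl, could not show. The two groups match in every count of atoms, donors and acceptors, so those counts do not separate them; only the way the atoms are joined differs. Nothing available explains why this change has so large an effect.

As far as these compounds go, whether pyridin-2-yl or a plain phenyl ring at this place would behave more like pyridin-3-yl or pyridin-4-yl remains open. Compound 3 gives 100% at a single concentration, which shows a strong effect at that concentration and says nothing about its effect at any other.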